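The source may hold more compounds than are shown below. What is called first, only, known or untested is meant among the compounds shown, and "the series" means these compounds.

Compound 1, `O=C1c2c(O)cc(O)cc2O[C@@H](c2cc(O)ccc2O)[C@@H]1O`, gives 25400 nM in a physicochemical assay, read by spectrophotometry, with a stated time of 30 min; a lower number here means that less compound is needed, a higher number that more compound is needed for the effect.
Compound 2, `O=C1c2c(O)cc(O)cc2O[C@@H](c2cccc(O)c2)[C@@H]1O`, gives only a limit of the assay, > 100000 nM, in this assay.
Compound 3, `COc1cccc([C@@H]2Oc3cc(O)cc(O)c3C(=O)[C@H]2O)c1`, likewise gives only a limit, > 100000 nM, in this assay.

Compound 2 thus sits at the limit of > 100000 nM in this assay, at which 2 of the 3 values shown sit; it is not a numbered value, and among the three compounds only compound 1 has a measured number. The unmeasured compound 4, `O=C1c2c(O)cc(O)cc2O[C@@H](c2cc(O)cc(O)c2)[C@@H]1O`, differs from compound 2 by one change: hydroxy in place of hydrogen on an aromatic carbon.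

For the measured compounds named here, two measured steps touch this region of the molecule. The step of an at least 3.9-fold higher number from compound 1 to compound 2 (0.59 log units; beyond the scatter) shows that taking a hydroxy away from the aromatic ring raised the number at least modestly. The step that the two limits leave unreadable from compound 2 to compound 3 cannot be read, as both of its values are limits. Putting a hydroxy back onto the ring, though at a different carbon than in compound 1, is expected to move the number in this assay downward, toward compound 1, but the new position makes the size uncertain and the result may stay at the limit. The expected step is an at least 1.2-fold lower number from compound 2 to compound 4 (0.09 log units; that floor lies within the scatter). Compound 4 is therefore estimated at 80000 nM, within 30000 nM to 200000 nM.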

Compound 4, half-maximal effective concentration: > 100000 nM
Compound 4: a limit, no number; the forecaster's own chance of this, stated with the estimate: 55%; middle value at least 1.2-fold (0.09 log units) from the limit.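

Compound 2 and compound 4 both give a limit rather than a number, so the step between them cannot be read: the limit of > 100000 nM in this assay, at which 3 of the 4 values shown sit. The compounds shown leave open whether the added hydroxy of compound 4 changes the number in this assay at all, and by how much.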